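From Cyclopropyl to Isobutyl in Compound 1

The source may report more compounds than this note shows. Statements on the series, on what has been measured and on what is new or still open speak of the compounds shown alone.

In a physicochemical assay for lipophilicity, using the shake flask method, at pH 7.4 (on this read-out higher numbers stand for higher lipophilicity and lower numbers for lower lipophilicity), compound 1 (`O=C(O)CCNC(=O)c1ccc(C(Oc2ccc(-n3cc(C(F)(F)F)cn3)cc2)C2CC2)cc1`) gives 1.7 and sits level with compound 3 (`CCCC(Oc1ccc(-n2cccn2)cc1)c1ccc(C(=O)NCCC(=O)O)cc1`) at 1.7 on this scale. Compound 2 (`CCCC(Oc1ccc(-n2cc3c(n2)CCCC3)cc1)c1ccc(C(=O)NCCC(=O)O)cc1`) reads 2.7 and so stands above both of them.

Compound 4 (`CC(C)CC(Oc1ccc(-n2cc(C(F)(F)F)cn2)cc1)c1ccc(C(=O)NCCC(=O)O)cc1`) has not been measured yet. Its structure departs from that of compound 1 in a single place, and the change is isobutyl in place of cyclopropyl on a saturated chain carbon bound to an aromatic carbon and an oxygen on an aromatic ring with the rest of the molecule untouched. The entering group has no ring and is the larger of the two.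

Within the data shown here, no measured step involves this site. Among the measured compounds shown here, the only measured step is a number 1.00 log units lower from compound 2 to compound 3 (beyond the scatter) and it lies beyond the scatter. That step puts a smaller group in place of a larger one on an aromatic carbon, at a different site, so it is only an indirect guide. Read in reverse, the step of a number 1.00 log units lower from compound 2 to compound 3 (beyond the scatter) suggests a rise of lesser size here, as the entering group is larger by less.

The expected change is a number 0.50 log units higher from compound 1 to compound 4 (beyond the scatter) as an estimate resting on that single indirect comparison. For compound 4 the estimated value is 2.2 with an expected range from 1.8 to 2.7 on this scale.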

Compound 4, distribution coefficient: 3.2
For compound 4 the middle estimate is 1.00 log units below the measured one; measured number above the stated range.
By their numbers in this assay, from the lowest: compounds 1 and 3 (each within the scatter of the next); then compound 2; then compound 4.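

Among these compounds, at the saturated chain carbon bound to an aromatic carbon and an oxygen on an aromatic ring, a site that no earlier step touched, isobutyl in place of cyclopropyl gives in this assay a number 1.50 log units higher from compound 1 to compound 4 (beyond the scatter). This shows that a small swap at this one place can shift the read-out strongly: the count of heavy atoms barely changes from cyclopropyl to isobutyl, yet the step is larger than the one at the other site, a number 1.00 log units lower from compound 2 to compound 3 (beyond the scatter), where the group changes far more in heavy atoms, so across these two steps the count of atoms alone does not set the size of the step. No measurement here explains why this swap has so large an effect.

The step combines two changes, the opening of the ring and the added carbon, and the compounds shown cannot separate them; a cyclobutyl group, which keeps a ring of carbon only, in the same place on compound 1 would speak to that. Also open, from the compounds shown here alone, is how this position responds to a group carrying other atoms, such as an amine or a methoxyethyl chain, in place of a group of carbon only.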